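A few compounds are considered here, and "the series" means these few. Any claim that something is new, unique, unknown or untested is made for them only; others in the source may bear on it.

Of the compounds shown here, three sharing one core have so far been tested in a functional assay on T47D cells (Homo sapiens) for cytotoxicity, read by sulforhodamine B assay, with a stated time of 48 h, tested at 100 uM; on this read-out higher numbers stand for a weaker effect at the one concentration tested and lower numbers for a stronger effect. Compound 1 `COc1cc(-c2cc(/C=C/C(=O)c3ccc(Cl)c(Cl)c3)[nH]n2)cc(OC)c1OC` gives -36%, the highest of the three numbers. Compound 2 `COc1ccc(-c2cc(/C=C/C(=O)c3ccc(N)cc3)[nH]n2)cc1OC` gives -40%, within the scatter of compound 1, while compound 3 `COc1ccc(-c2cc(/C=C/C(=O)c3ccc(N)cc3)[nH]n2)cc1` gives -54%, beyond the scatter from compound 1. For the measured compounds named here, the only step known between single-point neighbours, a number 14 percentage points lower from compound 2 to compound 3 (beyond the scatter), concerns hydrogen in place of methoxy on an aromatic carbon and leaves the carbonyl side untouched. Compound 4 `COc1ccc(C(=O)/C=C/c2cc(-c3cc(OC)c(OC)c(OC)c3)n[nH]2)cc1OC` differs from compound 1 by 3,4-dimethoxyphenyl in place of 3,4-dichlorophenyl on a carbonyl carbon. Going by the values given here, no measured step bears on this change: neither compound 2 nor compound 3 carries a 3,4-dimethoxyphenyl on the carbonyl carbon. A step no larger than the scatter is therefore expected, a number 2 percentage points lower from compound 1 to compound 4 (within the scatter). Compound 4 is estimated at -38%, with a range from -60% to -15%.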

Compound 4, a percentage reported as activity, at one concentration (the size of the read-out at that concentration, not a potency): -46%
For compound 4 the middle estimate is 8 percentage points above the measured one; low and high end bracket the measured number.
By their numbers in this assay, from the lowest: compounds 3, 4, 2 and 1 (each within the scatter of the next, the first and the last beyond it).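

In this assay, the first step read on the carbonyl side, 3,4-dimethoxyphenyl in place of 3,4-dichlorophenyl on a carbonyl carbon, gives a number 10 percentage points lower from compound 1 to compound 4 (within the scatter). The read-out at this position therefore stays within the scatter across this exchange, even though the two groups differ in their hydrogen-bond acceptors. Nothing available accounts for the size of this step.

Going by these compounds, it remains open whether a smaller or charged group on the carbonyl carbon, such as an unsubstituted phenyl or a carboxylic acid, would shift the number beyond the scatter.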